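The source may hold more compounds than are shown below. What is called first, only, known or untested is meant among the compounds shown, and "the series" means these compounds.

Working notes on the shared core, a benzamide bearing a methylsulfonyl and a nitro group and linked through an amide to a second carbonyl. Compound 1 `CN(Cc1ccccc1)C(=O)CNC(=O)c1ccc(S(C)(=O)=O)c([N+](=O)[O-])c1` gives in an assay on isolated protein for inhibition of vitamin D3 receptor (Homo sapiens), read by fluorescence polarization (on this read-out higher numbers stand for weaker inhibition and lower numbers for stronger inhibition), a result of > 60000 nM, which is a limit of the assay and not a number. Compound 2 `CS(=O)(=O)c1ccc(C(=O)NCC(=O)N2CCN(c3ccccc3F)CC2)cc1[N+](=O)[O-]` is reported in this assay only at > 60000 nM, again a limit of the assay. Both results therefore sit at the limit of > 60000 nM in this assay, at which 2 of the 2 values shown sit, so compound 2 cannot be placed relative to compound 1 on these numbers. Compound 3 `CN1CCN(C(=O)CNC(=O)c2ccc(S(C)(=O)=O)c([N+](=O)[O-])c2)CC1` differs from compound 2 by methyl in place of 2-fluorophenyl on an amine nitrogen in a ring. Going by the values given here, no step between measured compounds is available, and with both neighbours at the limit no step beyond the scatter is expected in this assay. The step from compound 2 to compound 3 is estimated as a step that the limit leaves unreadable from compound 2 to compound 3. Compound 3 is expected to give 90000 nM, within a range from 30000 nM to 300000 nM.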

Compound 3, half-maximal inhibitory concentration: > 60000 nM
Compound 3: only a limit was reported; the forecaster's own chance of this, stated with the estimate: 85%; the middle value is on the limit's open side.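

No step can be read among compound 1, compound 2 and compound 3, since all three stand at a limit of this assay and not at a number: the limit of > 60000 nM in this assay, at which 3 of the 3 values shown sit.

The compounds shown leave open how far apart these three lie and whether any group on the shared core gives a readable value.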